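Replacing bromo with pyridin-4-yl in compound 1

This account rests on a few compounds, and the source may have more. Where it says the series, first, only, none or still open, it means among the compounds named here.

Measured so far in an ADME assay on MT4 cells (Homo sapiens) for cytotoxicity, read by XTT assay, with a stated time of 5 days; a lower number here means that less compound is tolerated, a higher number that more compound is tolerated:
- compound 1 `CNC(=O)[C@@H](NC(=O)[C@@](O)(CCCN(Cc1ccc(Br)cc1)NC(=O)[C@@H](NC(=O)OC)C(C)(C)C)Cc1ccccc1)C(C)(C)C`: > 10000 nM (a limit)
- compound 2 `CNC(=O)[C@H](CC(C)C)NC(=O)[C@@](O)(CCCN(Cc1ccc(Br)cc1)NC(=O)[C@@H](NC(=O)OC)C(C)(C)C)Cc1ccccc1`: > 10000 nM (a limit)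
- compound 3 `CNC(=O)[C@@H](NC(=O)[C@@](CCCN(Cc1ccc(Br)cc1)NC(=O)[C@@H](NC(=O)OC)C(C)(C)C)(Cc1ccccc1)[Si](C)(C)C(C)(C)C)C(C)(C)C`: > 10000 nM (a limit)

Compound 1 gives > 10000 nM in this assay, which is a limit of the assay and not a number. Among the measured compounds shown here, the same holds for the other two compounds, so the series so far offers only (the limit of > 10000 nM in this assay, at which 3 of the 3 values shown sit).

The next compound to be tested is compound 4 `CNC(=O)[C@@H](NC(=O)[C@@](O)(CCCN(Cc1ccc(-c2ccncc2)cc1)NC(=O)[C@@H](NC(=O)OC)C(C)(C)C)Cc1ccccc1)C(C)(C)C`. Its difference from compound 1 is this: pyridin-4-yl in place of bromo on an aromatic carbon. In words, pyridin-4-yl stands in place of bromo on an aromatic carbon.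

Two measured steps start from compound 1: a step that the two limits leave unreadable from compound 1 to compound 2 and a step that the two limits leave unreadable from compound 1 to compound 3. Neither changes the bromo group, and neither has a size that can be read, so they offer no measured guide to this replacement. With no size to carry over, no step beyond the usual scatter is expected in either direction, and compound 4 is expected to lie close to the limit shared by the three measured compounds. The expected change is a step that the limit leaves unreadable from compound 1 to compound 4. For compound 4 the estimated value is 12000 nM, with an expected range of 5000 nM to 30000 nM.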

Compound 4, half-maximal cytotoxic concentration: > 50000 nM
Compound 4: only a limit was reported; the forecaster's own chance of this, stated with the estimate: 70%; middle value at least 4.1-fold (0.61 log units) away from the limit.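

In this assay compound 4 gives > 50000 nM, which is a limit of the assay. Compound 1 also stands at a limit, so the step between compound 1 and compound 4 cannot be read. The compounds shown leave open at what concentration any of them becomes cytotoxic to these cells, and whether pyridin-4-yl in place of bromo changes that concentration.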